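Compound 4: amino in place of methoxy, untested

A few compounds are considered here, and "the series" means these few. Any claim that something is new, unique, unknown or untested is made for them only; others in the source may bear on it.

Compound 1, `COC(=O)c1sc2cc(-c3ccsc3)cnc2c1N`: in a functional assay on NCI-H460 cells (Homo sapiens) for inhibition, read by sulforhodamine B assay, with a stated time of 48 h (on this read-out higher numbers stand for weaker inhibition of growth and lower numbers for stronger inhibition of growth), compound 1 gives 12400 nM.
Compound 2, `COC(=O)c1sc2cc(-c3cnn(C)c3)cnc2c1N`: compound 2 reaches only a limit, > 150000 nM.
Compound 3, `COC(=O)c1sc2cc(-c3ccc(OC)cc3)cnc2c1N`: compound 3 likewise reaches only a limit, > 150000 nM.

Among the three measured compounds, compound 1 is the only one with a number; compound 3 sits at the limit of > 150000 nM in this assay, at which 2 of the 3 values shown sit, so its standing is known only as a limit, with nothing to separate it from compound 2. Among the compounds with values here, the one measured step, an at least 12-fold higher number from compound 1 to compound 2 (1.08 log units; beyond the scatter), concerns a different ring exchange and does not touch the position that changes here.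

Compound 4, `COC(=O)c1sc2cc(-c3ccc(N)cc3)cnc2c1N`, differs from compound 3 by amino in place of methoxy on an aromatic carbon. Within the data shown here, no measured pair exchanges these two groups, so the expectation for this assay rests on the limit of compound 3 alone and is weak. Compound 4 is estimated at 120000 nM, with a range from 30000 nM to 300000 nM. The step this estimate means, an at least 1.2-fold lower number from compound 3 to compound 4 (0.09 log units; that floor lies within the scatter), is expected to lie within the scatter or to amount to a modest gain, and a second limit is thought more likely than a number.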

Compound 4, concentration for 50% growth inhibition: 37100 nM
For compound 4 the middle estimate is 3.2-fold (0.51 log units) above the measured one; measured number inside the range.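

In this assay, within the data shown here, the earlier compounds gave only a limit for a group on an aromatic carbon of the six-membered aromatic ring of carbon only, para to a large group, and the amino group is the first there to give a number, with amino in place of methoxy producing an at least 4.0-fold lower number from compound 3 to compound 4 (0.60 log units; beyond the scatter). The 4-aminophenyl group also separates from the 1-methyl-1H-pyrazol-4-yl group, with an at least 4.0-fold lower number from compound 2 to compound 4 (0.60 log units; beyond the scatter), yet it does not match the thiophen-3-yl group, with a 3.0-fold higher number from compound 1 to compound 4 (0.48 log units; beyond the scatter), so a single exchange on this ring recovers part of the growth inhibition but not all of the ground held by compound 1. The first two of these steps are known only as floors, and their full size cannot be read, since compound 2 and compound 3 both rest on a limit: the limit of > 150000 nM in this assay, at which 2 of the 4 values shown sit.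

Whether the gain belongs to amino alone stays open, as the compounds shown do not reveal how a hydroxyl, a dimethylamino or an acetylamino group would behave at the same place on the ring. As far as these compounds go, it also remains open whether an amino group carried on the thiophene ring of compound 1 would improve on that compound in the same way.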